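This account rests on a few compounds, and the source may have more. Where it says the series, first, only, none or still open, it means among the compounds named here.

Within the data shown here, in a functional assay on HepG2 cells for inhibition of squalene monooxygenase (Homo sapiens) (a lower number here means a stronger inhibitor, a higher number a weaker inhibitor), compound 3 `CCN(C/C=C/C#CC(C)(C)C)Cc1cccc(OCCN(C)S(=O)(=O)c2ccc(C#N)cc2)c1` gives 200 nM, the second highest of the three numbers measured so far. Its nearest neighbour is compound 2 `CCN(C/C=C/C#CC(C)(C)C)Cc1cccc(OCCN(C)S(=O)(=O)c2ccsc2)c1`, which gives 250 nM; the step of a 1.3-fold lower number from compound 2 to compound 3 (0.10 log units; within the scatter) lies within the scatter, so these two cannot be told apart. Compound 1 `CCN(C/C=C/C#CC(C)(C)C)Cc1cccc(OCCN(C)S(=O)(=O)c2cccs2)c1` gives 60 nM, and the step of a 3.3-fold higher number from compound 1 to compound 3 (0.52 log units; beyond the scatter) is beyond the scatter, making compound 1 the strongest inhibitor of the three. Compound 4 `CCN(C/C=C/C#CC(C)(C)C)Cc1cccc(OCCN(C)S(=O)(=O)c2cccnc2)c1` has not yet been measured. It differs from compound 3 in one place: pyridin-3-yl in place of 4-cyanophenyl on a sulfonyl sulfur. Among the measured compounds shown here, the steps that bear on this are the earlier swaps of the group on the sulfonyl sulfur, namely a 4.2-fold higher number from compound 1 to compound 2 (0.62 log units; beyond the scatter) and the two steps into compound 3 just given, all of them modest or within the scatter. None of them involves pyridin-3-yl, so the direction is open, and a step of similar modest size, or none beyond the scatter, is expected. For compound 4 the estimate in this assay is 200 nM, with a range of 70 nM to 600 nM, corresponding to an expected step of no change at the digits printed from compound 3 to compound 4 (within the scatter).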

Compound 4, half-maximal inhibitory concentration: 150 nM
Beside the measured number, compound 4's estimate is 1.3-fold (0.12 log units) above it, within the range that was stated.
By their numbers in this assay, from the lowest: compound 1; then compounds 4, 3 and 2 (each within the scatter of the next).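

Pyridin-3-yl is the only group here with a nitrogen in the ring itself, yet that change on the sulfonyl sulfur cannot be told from no change: a 1.3-fold lower number from compound 3 to compound 4 (0.12 log units; within the scatter) and a 1.7-fold lower number from compound 2 to compound 4 (0.22 log units; within the scatter). Thiophen-2-yl remains apart, with a 2.5-fold higher number from compound 1 to compound 4 (0.40 log units; beyond the scatter), so of the four groups compared at this position, it alone gives a number beyond the scatter of the others. Nothing measured here explains why this one group differs from the other three.

Still open, from the compounds shown here alone, is whether pyridin-2-yl or pyridin-4-yl, which carry the ring nitrogen elsewhere, would match pyridin-3-yl or come closer to thiophen-2-yl. Also open, going by these compounds, is how a group without an aromatic ring, such as a piperidine or a short alkyl chain, would compare on the sulfonyl sulfur.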